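This account rests on a few compounds, and the source may have more. Where it says the series, first, only, none or still open, it means among the compounds named here.

Measured compounds in a functional assay on the whole organism (artery, strain albino) with Rattus norvegicus as the target, with a stated time of 900 min, at a dose of 10 mg/kg by the oral route; on this read-out higher numbers stand for more inhibition at the one dose given (going by the name of the read-out) and lower numbers for less inhibition:

compound 1 `COc1ccc(C2N=C(SCc3ccc(F)cc3)NC(C)=C2C(=O)Nc2ccc(F)cc2)cc1OC` gives 15.4%
compound 2 `CC1=C(C(=O)Nc2ccc(F)cc2)C(c2ccc([N+](=O)[O-])cc2)N=C(SCc2ccccc2)N1` gives 21%
compound 3 `CC1=C(C(=O)Nc2ccc(F)cc2)C(c2ccc([N+](=O)[O-])cc2)N=C(SCc2ccc(Cl)cc2)N1` gives 16.9%

Compound 3 holds the second highest of the three numbers; its nearest neighbour is compound 1 and its furthest is compound 2, and both gaps are within the scatter, so the three compounds cannot be told apart on this read-out.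

Compound 4 `CC1=C(C(=O)Nc2ccc(F)cc2)C(c2ccc([N+](=O)[O-])cc2)N=C(SCc2ccc(F)cc2)N1` differs from compound 3 in one place: fluoro in place of chloro on an aromatic carbon. For the measured compounds named here, the only measured step that touches the same position is a number 4.1 percentage points lower from compound 2 to compound 3 (within the scatter), which sits within the scatter. Going by the values given here, no measured pair compares fluoro with chloro directly; compound 1 carries the fluoro group at this position but also differs from compound 3 elsewhere, so its value and that of compound 3 show only two numbers within the scatter of each other. The expectation in this assay is therefore no step beyond the scatter, with the estimated step being a number 0.1 percentage points higher from compound 3 to compound 4 (within the scatter). Compound 4 is estimated at 17%, within a range of 8% to 27%.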

Compound 4, a percentage reported as inhibition, in the whole organism at one dose (the size of the read-out at that dose, not a potency): 13.8%
Compound 4: middle estimate off by 3.2 percentage points, on the high side, within the range that was stated.
By their numbers in this assay, from the lowest: compounds 4, 1, 3 and 2 (each within the scatter of the next).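

This position now has a direct comparison of its halogens: in this assay, the change from 4-chlorobenzyl to 4-fluorobenzyl gives a number 3.1 percentage points lower from compound 3 to compound 4 (within the scatter), and fluoro in place of hydrogen gives a number 7.2 percentage points lower from compound 2 to compound 4 (within the scatter), so hydrogen, chloro and fluoro cannot be told apart here with the 4-nitrophenyl group held. With the 4-fluorobenzyl group held, the change on the saturated ring carbon gives a number 1.6 percentage points lower from compound 1 to compound 4 (within the scatter), so that position cannot be resolved on this read-out either. Nothing available bears on the reason for these numbers.

As far as these compounds go, whether any group at the aromatic carbon can move the number beyond the scatter remains open. An amine or a carboxylic acid there would test this, as would a longer chain in place of the benzyl group.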